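A few compounds are considered here, and "the series" means these few. Any claim that something is new, unique, unknown or untested is made for them only; others in the source may bear on it.

Measured in a functional assay on A549 cells (Homo sapiens) for antiproliferative activity, read by MTT assay, with a stated time of 72 h, in the presence of a further agent that is not named here; on this read-out lower numbers stand for stronger inhibition and higher numbers for weaker inhibition:
- compound 1 `Nc1nc2[nH]c(CCSCCC(=O)NCc3ccccn3)cc2c(=O)[nH]1`: 77300 nM
- compound 2 `Nc1nc2[nH]c(CCSCC(=O)N[C@@H](CCC(=O)O)C(=O)O)cc2c(=O)[nH]1`: 668 nM
- compound 3 `Nc1nc2[nH]c(CCSCCC(=O)NCc3cccnc3)cc2c(=O)[nH]1`: 1070 nM

Compound 2, at 668 nM, sits level with compound 3, at 1070 nM, within the usual scatter, and both lie far under compound 1, at 77300 nM.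

Compound 4 `Nc1nc2[nH]c(CCSCC(=O)NCc3ccncc3)cc2c(=O)[nH]1` differs from compound 2 only in the group on the amide-type nitrogen: (pyridin-4-yl)methyl in place of 1,3-dicarboxypropyl on an amide-type nitrogen. Here (pyridin-4-yl)methyl replaces 1,3-dicarboxypropyl, so the two carboxylic acid groups are lost and a pyridine ring arrives.

Among the compounds with values here, no measured step makes this exact change. The nearest evidence comes from the two pyridine compounds, which also differ from compound 4 in their chain. Their step, a 72-fold lower number from compound 1 to compound 3 (1.86 log units; beyond the scatter), is large, so the choice of pyridine attachment can matter greatly in this assay. Compound 3 suggests that a pyridine can match compound 2, whereas compound 1 shows how far it can fall short, so a moderate rise in the number seems likely.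

The estimated step is a 4.5-fold higher number from compound 2 to compound 4 (0.65 log units; beyond the scatter), towards weaker inhibition. For compound 4 the expected value is 3000 nM, with an estimated range of 500 nM to 30000 nM.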

Compound 4, half-maximal inhibitory concentration: 42400 nM
Compound 4: the middle estimate sits 14-fold (1.15 log units) below what was measured; measured number above the stated range.
By their numbers in this assay, from the lowest: compounds 2 and 3 (each within the scatter of the next); then compounds 4 and 1 (each within the scatter of the next).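

The swap of 1,3-dicarboxypropyl for (pyridin-4-yl)methyl on the amide-type nitrogen gives, in this assay, a 63-fold higher number from compound 2 to compound 4 (1.80 log units; beyond the scatter), towards weaker inhibition. Within the data shown here, the earlier step varied only the attachment of a pyridine, whereas this one is the first direct reading of what happens when the 1,3-dicarboxypropyl group is lost. It shows that, on the chain of compound 2, this pyridine group does not hold the level of compound 2, and nothing measured here explains the large rise.

From the compounds shown here alone, it remains open whether a simpler group with a single carboxylic acid, such as carboxymethyl, would keep the number of compound 2. Going by these compounds, it is also open whether the pyridin-3-yl attachment would give a different result on this same chain.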